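Swapping the aryl ring on the hydrazone carbon: compound 4

The source may report more compounds than this note shows. Statements on the series, on what has been measured and on what is new or still open speak of the compounds shown alone.

Measured so far in a functional assay on NCI-H460 cells (Homo sapiens) for cytotoxicity, read by MTT assay, with a stated time of 72 h; a higher number here means a weaker inhibitor, a lower number a stronger inhibitor:
- compound 1 `CN(C)CCn1cnnc1-c1cc(Oc2ccc(NC(=O)N/N=C/c3ccc(Cl)cc3Cl)cc2F)ccn1` gives 130 nM
- compound 2 `COc1ccc(/C=N/NC(=O)Nc2ccc(Oc3ccnc(-c4nncn4CCN(C)C)c3)c(F)c2)c(OC)c1` gives 1570 nM
- compound 3 `CN(C)CCn1cnnc1-c1cc(Oc2ccc(NC(=O)N/N=C/c3ccc(F)cc3F)cc2F)ccn1` gives 1930 nM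

Compound 3 has the highest number of the three. Its gap to compound 2 is small, a 1.2-fold higher number from compound 2 to compound 3 (0.09 log units; within the scatter), so the two cannot be told apart. Against compound 1 the gap is large, a 15-fold higher number from compound 1 to compound 3 (1.17 log units; beyond the scatter), and likewise a 12-fold higher number from compound 1 to compound 2 (1.08 log units; beyond the scatter), so compound 1 clearly stands out as the stronger of the set.

Compound 4 `CN(C)CCn1cnnc1-c1cc(Oc2ccc(NC(=O)N/N=C/c3cc(Br)c(O)c(Br)c3)cc2F)ccn1` differs from compound 3 only at the ring on the hydrazone carbon: 3,5-dibromo-4-hydroxyphenyl in place of 2,4-difluorophenyl on a carbon with a double bond to nitrogen. All three measured steps change exactly this ring, and they show it matters a great deal, with halogen-bearing compound 1 far ahead of the difluoro and dimethoxy compounds. For the measured compounds named here, compound 4 carries bromine at this ring, closer in kind to compound 1 than to compound 3, so a step downward from compound 3 is expected, of roughly a 3.9-fold lower number from compound 3 to compound 4 (0.59 log units; beyond the scatter), though the added hydroxyl has no precedent here. Compound 4 is therefore estimated at 500 nM, within 120 nM to 2500 nM.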

Compound 4, half-maximal inhibitory concentration: 3760 nM
Compound 4: middle estimate off by 7.5-fold (0.88 log units), on the low side; the measured number lies above the stated range.
By their numbers in this assay, from the lowest: compound 1; then compounds 2, 3 and 4 (each within the scatter of the next, the first and the last beyond it).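

Bromine on this ring does not bring back the strength of compound 1 (a 29-fold higher number from compound 1 to compound 4 (1.46 log units; beyond the scatter)) in this assay, so carrying halogen atoms here is not enough, and compounds 3 and 4 both go against any such pattern. Compound 4 instead stays with the weaker compounds: it cannot be told apart from the difluoro compound (a 1.9-fold higher number from compound 3 to compound 4 (0.29 log units; within the scatter)) and sits only modestly past the dimethoxy compound (a 2.4-fold higher number from compound 2 to compound 4 (0.38 log units; beyond the scatter)), which leaves 2,4-dichlorophenyl alone among these four rings in standing apart. Nothing available explains this difference between the rings.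

The effects of the two bromines and the hydroxyl remain tangled in compound 4, and a 3,5-dibromophenyl ring would help separate them. A 2,4-dibromophenyl or 3,5-dichlorophenyl ring would show whether the gain of compound 1 follows the chlorine atoms or their placement.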